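A Chloro Group Added to Compound 2

The source may report more compounds than this note shows. Statements on the series, on what has been measured and on what is new or still open speak of the compounds shown alone.

Two measured compounds set the scene. In a functional assay on MCF7 cells (Homo sapiens) for antiproliferative activity, read by MTT assay, with a stated time of 48 h (a higher number here means a weaker inhibitor, a lower number a stronger inhibitor), compound 1 `Cc1ccc(/C=C/C(=O)Nc2nnc(-c3ccc(Cl)cc3)s2)cc1` gives 1.44 ug/mL, and compound 2 `O=C(/C=C/c1ccc(C(F)(F)F)cc1)Nc1nnc(-c2ccccc2)s1` gives 1.52 ug/mL. These two numbers lie within the usual scatter of each other, so compound 2 stands level with compound 1, and neither can be called the better inhibitor. The pair differs in more than one place, so no single structural change can be read from it.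

The next compound is compound 3 `O=C(/C=C/c1ccc(C(F)(F)F)cc1)Nc1nnc(-c2ccc(Cl)cc2)s1`. It matches compound 2 except for one change: chloro in place of hydrogen on an aromatic carbon. This is chloro in place of hydrogen on an aromatic carbon, para to a large group, which turns phenyl into 4-chlorophenyl. Compound 1 also carries 4-chlorophenyl and gives 1.44 ug/mL, which offers no sign of a large shift. This change has not been measured on its own, so the expectation in this assay is a slight lowering of the number and no step beyond the scatter. The estimated step is a 1.2-fold lower number from compound 2 to compound 3 (0.07 log units; within the scatter). For compound 3 the expected value is 1.3 ug/mL, with an estimated range from 0.6 ug/mL to 2.8 ug/mL.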

Compound 3, half-maximal inhibitory concentration: 1.65 ug/mL
The estimate for compound 3 lay 1.3-fold (0.10 log units) below the measured number; measured number inside the range.
By their numbers in this assay, from the lowest: compounds 1, 2 and 3 (each within the scatter of the next).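

In this assay, adding chloro to the phenyl ring, para to a large group, gives a 1.1-fold higher number from compound 2 to compound 3 (0.04 log units; within the scatter), so in this setting the change from phenyl to 4-chlorophenyl has no effect that can be told apart from ordinary assay variation. Compound 3 also makes a second single change readable, trifluoromethyl in place of methyl on an aromatic carbon, which gives a 1.1-fold higher number from compound 1 to compound 3 (0.06 log units; within the scatter), and this swap likewise shows no effect that can be separated from that variation. There is no independent measurement here that could explain why either change leaves the number within the scatter.

Only hydrogen and chloro are shown at the first place, and only methyl and trifluoromethyl at the second, so it remains open whether a quite different group at either place, such as an amine, a carboxylic acid or a longer chain, would move the number beyond the scatter. Because all three compounds sit within the scatter of one another, these results also leave open which parts of the structure, if any, this antiproliferative read-out depends on.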